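This account rests on a few compounds, and the source may have more. Where it says the series, first, only, none or still open, it means among the compounds named here.

In an ADME assay on L1210/0 cells (Mus musculus) for cytotoxicity, with a stated time of 48 h (a lower number here means a stronger inhibitor, a higher number a weaker inhibitor), two compounds on a shared core have been measured so far. Compound 1 (`Cc1cn(COCCO)c(=O)[nH]c1=O`) gives > 200000 nM, which is a limit of the assay and not a number. Compound 2 (`O=c1[nH]c(=O)n(COCCO)cc1[N+](=O)[O-]`) gives > 200000 nM, which is likewise a limit and not a number. Compound 2 therefore has no readable position, and the whole picture so far is the limit of > 200000 nM in this assay, at which 2 of the 2 values shown sit.

The next compound, compound 3 (`O=c1ccn(COCCO)c(=O)[nH]1`), carries hydrogen in place of nitro on an aromatic carbon. Within the data shown here, only one measured step bears on this, the nitro in place of methyl change a step that the two limits leave unreadable from compound 1 to compound 2, and it offers no size to carry over.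

With compound 2 at the limit of > 200000 nM, no step beyond the scatter can be argued for, and none is expected in either direction. The estimated step is a step that the limit leaves unreadable from compound 2 to compound 3. Compound 3 is expected near 250000 nM, with an estimated range from 100000 nM to 500000 nM. A report of only a limit is the likeliest outcome.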

Compound 3, half-maximal inhibitory concentration: > 200000 nM
Compound 3 was reported as a limit (the forecaster's own chance of this, stated with the estimate: 85%); the middle value is on the limit's open side.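

Among these compounds, no step among compound 1, compound 2 and compound 3 can be read, because all three are reported only as limits of the assay and not as numbers: the limit of > 200000 nM in this assay, at which 3 of the 3 values shown sit.

The compounds shown leave open whether methyl, nitro or hydrogen on this aromatic carbon makes any difference in this assay and how far each compound lies past the limit.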